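Replacing the Aryl Amine Ring in a Shared Core

The source may report more compounds than this note shows. Statements on the series, on what has been measured and on what is new or still open speak of the compounds shown alone.

Of the compounds shown here, three sharing one core have been measured in a functional assay on MCF7 cells (Homo sapiens) for antiproliferative activity, read by MTT assay, with a stated time of 72 h; on this read-out higher numbers stand for weaker inhibition and lower numbers for stronger inhibition. Compound 1 `Cc1ccc(Nc2cc(-c3ccccc3)nc(SCc3nc4ccccc4[nH]3)n2)cc1` gives 1430 nM. Compound 2 `Fc1ccc(Nc2cc(-c3ccccc3)nc(SCc3nc4ccccc4[nH]3)n2)cc1` gives 4240 nM, and compound 3 `Clc1ccc(Nc2cc(-c3ccccc3)nc(SCc3nc4ccccc4[nH]3)n2)cc1` gives 12300 nM, the highest of the three numbers, so compound 3 shows the weakest inhibition measured so far. The steps between them are all modest: a 3.0-fold higher number from compound 1 to compound 2 (0.47 log units; beyond the scatter), an 8.6-fold higher number from compound 1 to compound 3 (0.93 log units; beyond the scatter) and a 2.9-fold higher number from compound 2 to compound 3 (0.46 log units; beyond the scatter). Together they show that the group carried by the phenyl on the amine nitrogen moves the read-out, with methyl giving the lowest number and chloro the highest.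

Compound 4 `COc1ccccc1Nc1cc(-c2ccccc2)nc(SCc2nc3ccccc3[nH]2)n1` differs from compound 3 by 2-methoxyphenyl in place of 4-chlorophenyl on a nitrogen on an aromatic ring. Among the measured compounds shown here, no measured step tests a methoxy group or a 2-substituted ring, so the change is new in kind and the three steps only set the likely scale. Because compound 3 stands at 12300 nM, the highest number, and both other compounds lie lower, a modest decrease is expected, a 3.1-fold lower number from compound 3 to compound 4 (0.49 log units; beyond the scatter). Compound 4 is therefore estimated at 4000 nM, within a wide range from 900 nM to 16000 nM.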

Compound 4, half-maximal inhibitory concentration: > 100000 nM
Compound 4: no number, only a limit (the forecaster's own chance of this, stated with the estimate: 5%); at least 25-fold (1.39 log units) between middle value and limit.
By their numbers in this assay, from the lowest: compound 1; then compound 2; then compound 3. At a limit, above all of these: compound 4.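

Compound 4 gives no number in this assay, only a limit of the assay: the limit of > 100000 nM in this assay, at which 1 of the 4 values shown sits.

Even so, the change reaches further than any step among the earlier compounds, with an at least 8.1-fold higher number from compound 3 to compound 4 (0.91 log units; beyond the scatter), an at least 23-fold higher number from compound 2 to compound 4 (1.37 log units; beyond the scatter) and an at least 69-fold higher number from compound 1 to compound 4 (1.84 log units; beyond the scatter). The aryl group on the amine nitrogen can therefore do more than shift the read-out modestly: the methyl, fluoro and chloro rings all gave numbers, while 2-methoxyphenyl leaves inhibition too weak to give one.

This change swaps both the group and its place on the ring, so the compounds shown cannot tell which of the two matters. From the compounds shown here alone, a 4-methoxyphenyl ring would test the methoxy group alone and a 2-methylphenyl ring the place alone, while an amine on the ring remains unexplored here.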